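The source may hold more compounds than are shown below. What is called first, only, known or untested is meant among the compounds shown, and "the series" means these compounds.

Measured in an ADME assay for permeability, using PAMPA, at pH 4; a lower number here means that the compound crosses the layer more slowly, a higher number that the compound crosses the layer faster:
compound 1 `Cc1[nH]c2ccccc2c(=O)c1C1CCCCC1` gives 260 10^-6 cm/s
compound 2 `Cc1[nH]c2ccc(F)cc2c(=O)c1Br` gives 16.2 10^-6 cm/s
compound 3 `CCCCC#Cc1c(C)[nH]c2ccccc2c1=O` gives 500 10^-6 cm/s

Compound 3 and compound 1 lie within the scatter of each other, and both stand far above compound 2. Compound 4 `CCCCC#Cc1c(C)[nH]c2ccc(F)cc2c1=O` keeps the hex-1-yn-1-yl group of compound 3 and differs from it as follows: fluoro in place of hydrogen on an aromatic carbon.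

For the measured compounds named here, no measured pair isolates this change. Going by the values given here, the only measured step, a 1.9-fold higher number from compound 1 to compound 3 (0.28 log units; within the scatter), concerns a different change, hex-1-yn-1-yl in place of cyclohexyl, so it bears on the new step only indirectly. Compound 2 also carries fluoro, but it lacks the hex-1-yn-1-yl group as well, so its 16.2 10^-6 cm/s cannot be read as a measure of the fluoro alone.

With nothing pointing in either direction, the expectation starts from compound 3 at 500 10^-6 cm/s and foresees no step beyond the scatter in this assay. The expected step is a 1.3-fold lower number from compound 3 to compound 4 (0.12 log units; within the scatter). Compound 4 is estimated at 380 10^-6 cm/s, with an expected range of 150 10^-6 cm/s to 750 10^-6 cm/s.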

Compound 4, apparent permeability: 314 10^-6 cm/s
For compound 4 the middle estimate is 1.2-fold (0.08 log units) above the measured one; measured number inside the range.
By their numbers in this assay, from the lowest: compound 2; then compounds 1, 4 and 3 (each within the scatter of the next).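

In this assay, the change of fluoro in place of hydrogen on an aromatic carbon, meta to a fused ring and para to a fused ring, can now be read on its own: a 1.6-fold lower number from compound 3 to compound 4 (0.20 log units; within the scatter). For the compounds shown here, with the hex-1-yn-1-yl group held constant, this position therefore tolerates fluoro without a shift beyond the scatter, which the earlier compounds could not show. Compound 4 also gives a second single-place comparison with fluoro held constant, a 19-fold higher number from compound 2 to compound 4 (1.29 log units; beyond the scatter), for hex-1-yn-1-yl in place of bromo on an aromatic carbon, so among these compounds the low number of compound 2 goes with the bromo rather than with the fluoro, although no measurement shown here explains either step.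

On these data alone, the fluoro step rests on a single pair carrying the hex-1-yn-1-yl group, so whether it stays as small alongside cyclohexyl or bromo remains open. Also open, as far as these compounds go, is how the number would respond to a different group at the fluoro position, such as an amine or a carboxylic acid.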